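The compounds below may be only part of what the source reports. "The series", "measured", "known", "first", "only" and "open" are said of these compounds alone.

Of the compounds shown here, three built on one shared core have been measured in a functional assay on L1210 cells (Mus musculus), with a stated time of 12 days; on this read-out higher numbers stand for higher potency (the scale is a negative logarithm) and lower numbers for lower potency. Compound 2 `CCOC(COC(N)=O)C1=C(N2CC2)C(=O)C(C)=C(N2CC2)C1=O` gives 6.18, the highest of the three numbers. Compound 1 `CCCC1=C(N2CC2)C(=O)C(C(COC(N)=O)OC)=C(N2CC2)C1=O` comes nearest, and in this assay compound 1 gives 5.63, a gap that lies beyond the usual scatter of this kind of measurement. Compound 3 `CC1=C(N2CC2)C(=O)C(CCCc2ccccc2)=C(N2CC2)C1=O` stands furthest away; in this assay compound 3 gives 4.47, again beyond the scatter.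

Compound 4 `CCC(COC(N)=O)C1=C(N2CC2)C(=O)C(C)=C(N2CC2)C1=O` has not yet been measured. It differs from compound 2 in a single place: ethyl in place of ethoxy on a saturated chain carbon bound to a double-bonded ring carbon and a saturated chain carbon. Going by the values given here, no pair of measured compounds differing in just one place is available, so nothing in the data directly shows what such a change does; the expectation rests on compound 2 alone and on the nature of the change. A modest loss in this assay is expected, of a size that may or may not exceed the scatter. Compound 4 is therefore expected to reach about 5.8, with a likely range from 5.2 to 6.4. That estimate corresponds to an expected step of a number 0.38 log units lower from compound 2 to compound 4 (beyond the scatter).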

Compound 4, logarithm of the reciprocal of the active concentration, log(1/C): 6.18
For compound 4 the middle estimate is 0.38 log units below the measured one; low and high end bracket the measured number.
By their numbers in this assay, from the lowest: compound 3; then compound 1; then compounds 2 and 4 (each within the scatter of the next).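

In this assay ethyl in place of ethoxy gives no change at the digits printed from compound 2 to compound 4 (within the scatter) on a saturated chain carbon bound to a double-bonded ring carbon and a saturated chain carbon. Going by these compounds alone, this is the first comparison here in which only one place differs, and it shows that, for this pair, potency in this read-out does not depend on the oxygen of ethoxy, the one hydrogen-bond acceptor that leaves with the change. Nothing measured here explains why the two groups match.

Other groups at this carbon, such as a hydroxyl, an amine or a longer chain like butyl, remain open. On these data alone, this is also a single pair, so whether the same swap holds when other parts of the shared core differ is unknown.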